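A few compounds are considered here, and "the series" means these few. Any claim that something is new, unique, unknown or untested is made for them only; others in the source may bear on it.

Measured so far:
- compound 1 `CCC(=O)O[C@@H](/C(C)=C/[C@@H](C)c1oc(CC)c(C)c(=O)c1C)[C@H](C)[C@@H](OC(=O)CC(C)C)[C@@H](C)c1oc([C@@H](C)[C@@H](O)CC)c(C)c(=O)c1C`: 12000 nM
- compound 2 `CCc1oc([C@H](C)/C=C(\C)[C@H](O)[C@H](C)[C@@H](OC(=O)CC(C)C)[C@@H](C)c2oc([C@@H](C)[C@@H](O)CC)c(C)c(=O)c2C)c(C)c(=O)c1C`: > 100000 nM
- compound 3 `CCC(=O)O[C@@H](/C(C)=C/[C@@H](C)c1oc(CC)c(C)c(=O)c1C)[C@H](C)[C@@H](OC(=O)CC(C)C)[C@@H](C)c1oc([C@@H](C)[C@H](CC)OC(C)=O)c(C)c(=O)c1C`: 4000 nM

All three were run in a functional assay on MCF7 cells (Homo sapiens) for inhibition, read by MTT assay, with a stated time of 72 h; on this read-out lower numbers stand for stronger inhibition and higher numbers for weaker inhibition. In this assay compound 1 gives 12000 nM and compound 3 gives 4000 nM. For compound 2 only a limit of the assay is recorded, > 100000 nM, which is the limit at which one of the three values shown sits (the limit of > 100000 nM in this assay, at which 1 of the 3 values shown sits).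

Within the data shown here, compound 2 differs from compound 1 by hydrogen in place of propanoyl on an oxygen on a saturated carbon; this step, an at least 8.3-fold higher number from compound 1 to compound 2 (0.92 log units; beyond the scatter), is the only change between the two cores that is counted here. Compound 3 differs from compound 1 by acetyl in place of hydrogen on an oxygen on a saturated carbon, and that step reads a 3.0-fold lower number from compound 1 to compound 3 (0.48 log units; beyond the scatter).

Not yet measured is compound 4 `CCc1oc([C@H](C)/C=C(\C)[C@H](OC(C)=O)[C@H](C)[C@@H](OC(=O)CC(C)C)[C@@H](C)c2oc([C@@H](C)[C@@H](O)CC)c(C)c(=O)c2C)c(C)c(=O)c1C`. It differs from compound 2 by acetyl in place of hydrogen on an oxygen on a saturated carbon, the same change as from compound 1 to compound 3; the surroundings of the place read the same in both cases. Because the measured example of this change gave a 3.0-fold lower number from compound 1 to compound 3 (0.48 log units; beyond the scatter), a step of similar direction is expected from compound 2 to compound 4, an at least 3.3-fold lower number from compound 2 to compound 4 (0.52 log units; beyond the scatter); since compound 2 is known only as a limit, the starting point of that step is itself uncertain. Compound 4 is thus estimated at 30000 nM in this assay, with a range of 8000 nM to 100000 nM expected.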

Compound 4, half-maximal inhibitory concentration: 15000 nM
Beside the measured number, compound 4's estimate is 2.0-fold (0.30 log units) above it; measured number inside the range.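

The new step reads an at least 6.6-fold lower number from compound 2 to compound 4 (0.82 log units; beyond the scatter) in this assay, so acetyl in place of hydrogen on an oxygen on a saturated carbon moves the number in the same direction on the second core as on the first. The direction of this change carries over between the two cores shown, but its size cannot be compared: the same change on two cores in this assay, a 3.0-fold lower number (0.48 log units; beyond the scatter) from compound 1 to compound 3 and an at least 6.6-fold lower number (0.82 log units; beyond the scatter) from compound 2 to compound 4; the limit leaves it open whether they differ. Compound 2 is recorded only as a limit, so the new step gives a bound and not a size: the limit of > 100000 nM in this assay, at which 1 of the 4 values shown sits.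

From the compounds shown here alone, with propanoyl and acetyl compared on the same oxygen, the step reads a 1.3-fold higher number from compound 1 to compound 4 (0.10 log units; within the scatter), so the two esters are not told apart in this assay, and it stays open whether a longer chain such as butanoyl, or an ester carrying an amine or a carboxylic acid, would read the same. Also open, going by these compounds, is whether the change holds on cores beyond these two, since two examples, one of them resting on a limit, give a direction on these compounds only and no rule for the series.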